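The source may hold more compounds than are shown below. What is called first, only, known or untested is meant among the compounds shown, and "the series" means these compounds.

The measured compounds:
Compound 1 `CCCCc1cnc(C(CCCO)Cc2ccc(-c3ccccc3C(=O)O)cc2)[nH]1` in an in vitro functional assay on cells for agonist activity at Bombesin receptor subtype-3 (Mus musculus), read by luminescence and calcium flux (on this read-out higher numbers stand for an effect only at larger amounts of compound and lower numbers for an effect already at smaller amounts), gives 238 nM.
Compound 2 `CCCCc1cnc(CCc2ccc(-c3ccccc3C(=O)O)cc2)[nH]1` gives 93 nM.
Compound 3 `CCCCc1cnc(C(C)Cc2ccc(-c3ccccc3C(=O)O)cc2)[nH]1` gives 184 nM.

Compound 2 has the lowest of these three numbers: against compound 1 the step is a 2.6-fold lower number from compound 1 to compound 2 (0.41 log units; beyond the scatter), while toward compound 3 it is a 2.0-fold higher number from compound 2 to compound 3 (0.30 log units; within the scatter), a gap within the scatter, so compound 2 and compound 3 cannot be ranked against each other.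

Compound 4 `O=C(O)c1ccccc1-c1ccc(CCc2ncc(Cc3ccccc3Cl)[nH]2)cc1` is not yet measured. It differs from compound 2 by 2-chlorophenyl in place of propyl on a saturated chain carbon bound to an aromatic carbon. Every measured step alters a saturated chain carbon bound to an aromatic carbon or the carbon two bonds along that chain; none touches the butyl that changes in compound 4. For the measured compounds named here, no measured step therefore bears on this change, and no direction can be read from the data. Compound 4 is expected to give a number close to that of compound 2, with a wide range: 93 nM, spanning 25 nM to 350 nM. The step this estimate implies, no change at the digits printed from compound 2 to compound 4 (within the scatter), is expected to stay within the scatter.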

Compound 4, half-maximal effective concentration: 22 nM
Beside the measured number, compound 4's estimate is 4.2-fold (0.63 log units) above it; measured number outside the range, below it.
By their numbers in this assay, from the lowest: compound 4; then compounds 2, 3 and 1 (each within the scatter of the next, the first and the last beyond it).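

In this assay, replacing butyl with 2-chlorobenzyl gives a 4.2-fold lower number from compound 2 to compound 4 (0.63 log units; beyond the scatter). For the compounds shown here, this shows that the number responds to the group at this position, which no earlier step had changed, and that a larger group containing an aromatic ring can give a lower number than the plain chain. Nothing available explains this shift.

The change brings in the ring and the chlorine together, and the compounds shown do not separate their contributions. Going by these compounds, how a plain benzyl group or a longer chain such as hexyl would read at this position remains open.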